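Swapping cyclopentyl for 4-methylphenyl on an amine nitrogen

The compounds below may be only part of what the source reports. "The series", "measured", "known", "first", "only" and "open" are said of these compounds alone.

In a functional assay on MGC-803 cells (Homo sapiens) for inhibition, read by sulforhodamine B assay (on this read-out lower numbers stand for stronger inhibition and higher numbers for weaker inhibition), compound 1 `O=C1C=C(NCc2ccccc2)C(=O)c2c1nc1n2[C@H]2OC[C@@H](O)[C@H]2OC1` gives 2670 nM. Compound 2 `O=C1C=C(N2CCC2)C(=O)c2c1nc1n2[C@H]2OC[C@@H](O)[C@H]2OC1` gives > 16000 nM, which is a limit and not a number. Compound 3 `O=C1C(NC2CCCC2)=CC(=O)c2c1nc1n2[C@H]2OC[C@@H](O)[C@H]2OC1` gives > 16000 nM, which is also a limit. That places compound 3 at the limit of > 16000 nM in this assay, at which 2 of the 3 values shown sit, so it has no exact value to start from.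

Compound 4 `Cc1ccc(NC2=CC(=O)c3c(nc4n3[C@H]3OC[C@@H](O)[C@H]3OC4)C2=O)cc1` differs from compound 3 in one place: 4-methylphenyl in place of cyclopentyl on an amine nitrogen. In short, 4-methylphenyl stands in place of cyclopentyl on an amine nitrogen. Within the data shown here, no measured step makes this exact swap. Among the measured compounds shown here, the nearest evidence is an at least 5.9-fold higher number from compound 1 to compound 2 (0.77 log units; beyond the scatter), a step that removes benzylamino, and compound 1 is the only measured compound with a real number. On that thin basis, a modest shift towards a lower number is expected, though compound 4 could still reach the limit. The step expected is an at least 1.7-fold lower number from compound 3 to compound 4 (0.24 log units; that floor lies within the scatter). For compound 4 the estimated value is 9000 nM, with an expected range from 2500 nM to 30000 nM.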

Compound 4, half-maximal inhibitory concentration: 1550 nM
The estimate for compound 4 lay 5.8-fold (0.76 log units) above the measured number; measured number outside the range, below it.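

At this amine nitrogen, the group carried on the nitrogen clearly matters in this assay: (4-methylphenyl)amino in place of cyclopentylamino gives an at least 10-fold lower number from compound 3 to compound 4 (1.01 log units; beyond the scatter). Among these compounds, until now, the only step available removed a benzylamino group, whereas this one keeps the rest of the compound unchanged and shows that exchanging one ring for another on the same nitrogen can move a compound from the limit to a real number. The size of this step remains a floor, as its starting point is a limit and not a number: the limit of > 16000 nM in this assay, at which 2 of the 4 values shown sit.

The compounds shown leave open how plain phenyl on the same nitrogen would compare with 4-methylphenyl, which would tell whether the methyl counts. They also leave open how a longer chain such as n-hexyl would read here.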